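The source may hold more compounds than are shown below. What is called first, only, known or untested is meant among the compounds shown, and "the series" means these compounds.

Of the compounds shown here, two with a shared core have been measured in a functional assay on KOPN-8 cells (Homo sapiens) for antiproliferative activity, with a stated time of 72 h; on this read-out higher numbers stand for an effect only at larger amounts of compound and lower numbers for an effect already at smaller amounts. Compound 1, `COc1ccc(-c2[nH]c3cc(OC)cc(OC)c3c(=O)c2I)cc1`, gives 49400 nM in this assay. Compound 2, `COc1ccc(-c2cc(=O)c3c(OC)cc(OC)cc3n2S(=O)(=O)c2ccc([N+](=O)[O-])cc2)cc1`, gives 17300 nM. Of these two numbers, that of compound 2 is the lower, and the gap between the two lies beyond the usual scatter of the assay. A third compound, compound 3, `COc1ccc(-c2cc(=O)c3c(OC)cc(OC)cc3n2S(=O)(=O)c2ccc(Br)cc2)cc1`, has not yet been measured in this assay. It differs from compound 2 in one place only: bromo in place of nitro on an aromatic carbon. Within the data shown here, no measured pair shows a change of this kind, so there is no step to lean on, and the expectation rests on the structures alone. A small group with no hydrogen-bond acceptors takes the place of one with two; a step of modest size is expected, if any, and in either direction the change may well stay within the scatter. Compound 3 is therefore expected to give about 15000 nM in this assay, with a range from 5000 nM to 50000 nM, which means an expected step of a 1.2-fold lower number from compound 2 to compound 3 (0.06 log units; within the scatter).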

Compound 3, half-maximal effective concentration: > 86200 nM
Compound 3 gave a limit, no number (the forecaster's own chance of this, stated with the estimate: 10%); at least 5.7-fold (0.75 log units) between middle value and limit.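

In this assay, compound 3 gives > 86200 nM, and this value is a limit of the assay, not a number. Going from 4-nitrophenyl to 4-bromophenyl, on an aromatic carbon para to a large group, comes with an at least 4.9-fold higher number from compound 2 to compound 3 (0.69 log units; beyond the scatter), which shows that the read-out is sensitive to what sits at this place, something the earlier compounds could not show because they offered no pair differing here in one place alone. The true size of the step stays unknown, and how far it reaches rests on a single limit: the limit of > 86200 nM in this assay, at which 1 of the 3 values shown sits.

The compounds shown leave open how an amine, a nitrile or a carboxylic acid on this carbon would read in this assay, and whether plain hydrogen there would fall nearer to compound 2 or to compound 3. They also leave open whether the same exchange of nitro for bromo would have a similar effect on a different core or in other cells.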